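Notes on an amide series: aryl-methyl swap on the amide nitrogen

The compounds below may be only part of what the source reports. "The series", "measured", "known", "first", "only" and "open" are said of these compounds alone.

Measured compounds:
compound 1 `CCN(Cc1cccs1)C(=O)COc1ccc(C)cc1` — 8 nM
compound 2 `Cc1ccc(OCC(=O)N(Cc2cccs2)CC(C)C)cc1` — 900 nM

In an assay on HEK293 cells for agonist activity at transient receptor potential cation channel subfamily M member 8 (Homo sapiens), read by fluorescence and calcium flux, with a stated time of 15 min (a higher number here means that more compound is needed for the effect, a lower number that less compound is needed), compound 1 gives 8 nM, the lowest of the two numbers; the nearest is compound 2 with 900 nM, a step of a 110-fold higher number from compound 1 to compound 2 (2.05 log units; beyond the scatter). Compound 3 `CCN(Cc1c[nH]nn1)C(=O)COc1ccc(C)cc1` differs from compound 1 by 1H-1,2,3-triazol-4-yl in place of thiophen-2-yl on a saturated chain carbon bound to an amide-type nitrogen. Going by the values given here, no measured step touches this position; the only step in hand, a 110-fold higher number from compound 1 to compound 2 (2.05 log units; beyond the scatter), concerns a different place and gives no direction for a ring swap. For compound 3 a loss of a 25-fold higher number from compound 1 to compound 3 (1.40 log units; beyond the scatter) is therefore an estimate with wide uncertainty, expected to land at 200 nM within 20 nM to 3000 nM.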

Compound 3, half-maximal effective concentration: 31100 nM
The estimate for compound 3 lay 160-fold (2.19 log units) below the measured number; the measured number lies above the stated range.
By their numbers in this assay, from the lowest: compound 1; then compound 2; then compound 3.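

At this position, on a saturated chain carbon bound to an amide-type nitrogen, the two five-membered aromatic rings are not interchangeable in this assay, with a 3900-fold higher number from compound 1 to compound 3 (3.59 log units; beyond the scatter) for 1H-1,2,3-triazol-4-yl in place of thiophen-2-yl. The rings match in size, so ring size alone does not set the number; they differ in their hetero atoms and hydrogen-bond donor count, and these two differences cannot be separated here. No evidence in hand accounts for the change. Open, on these data alone, is how a phenyl ring, a furan-2-yl ring or a 1-methyl-1,2,3-triazol-4-yl ring would read at this position.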